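A few compounds are considered here, and "the series" means these few. Any claim that something is new, unique, unknown or untested is made for them only; others in the source may bear on it.

Compound 1 `O=C(Nc1ccc([N+](=O)[O-])cc1)Nc1cccc(CNc2ncnc3ccccc23)c1` was examined in a functional assay on A549 cells (Homo sapiens) for antiproliferative activity, read by MTT assay; a higher number here means a weaker inhibitor, a lower number a stronger inhibitor. In this assay compound 1 gives only a limit, > 50000 nM. Compound 2 `O=C(Nc1cccc(CNc2ncnc3ccccc23)c1)Nc1cccc(C(F)(F)F)c1` differs from it by 3-(trifluoromethyl)phenyl in place of 4-nitrophenyl on an amide-type nitrogen, and in this assay compound 2 gives 44200 nM. This change made an at least 1.1-fold lower number from compound 1 to compound 2 (0.05 log units; that floor lies within the scatter), and the floor on that step rests on (the limit of > 50000 nM in this assay, at which 2 of the 3 values shown sit). Compound 3 `COc1cc2ncnc(NCc3cccc(NC(=O)Nc4ccc([N+](=O)[O-])cc4)c3)c2cc1OC` has a different core from compound 1; the difference between the two cores is not broken down here. In this assay compound 3 gives only a limit, > 50000 nM. Compound 4 `COc1cc2ncnc(NCc3cccc(NC(=O)Nc4cccc(C(F)(F)F)c4)c3)c2cc1OC` is compound 3 with 3-(trifluoromethyl)phenyl in place of 4-nitrophenyl on an amide-type nitrogen, the same change as before. Resting on the earlier at least 1.1-fold lower number from compound 1 to compound 2 (0.05 log units; that floor lies within the scatter), the estimate means an at least 1.0-fold lower number from compound 3 to compound 4 (0.01 log units; that floor lies within the scatter). Compound 4 is therefore expected to give 48000 nM in this assay, with a likely range from 25000 nM to 100000 nM.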

Compound 4, half-maximal inhibitory concentration: 35300 nM
The estimate for compound 4 lay 1.4-fold (0.13 log units) above the measured number; low and high end bracket the measured number.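

In this assay, 3-(trifluoromethyl)phenyl in place of 4-nitrophenyl on an amide-type nitrogen gave an at least 1.4-fold lower number from compound 3 to compound 4 (0.15 log units; that floor lies within the scatter). Set beside the step on the core of compound 1, this gives two floors, neither of which is printed as going beyond the scatter, so the change is not shown to differ between the two cores: the same change on two cores in this assay, an at least 1.1-fold lower number (0.05 log units; that floor lies within the scatter) from compound 1 to compound 2 and an at least 1.4-fold lower number (0.15 log units; that floor lies within the scatter) from compound 3 to compound 4; the limit leaves it open whether they differ. Nor does it show that the change carries over by the same amount, since each step starts from a limit and not from a number: the limit of > 50000 nM in this assay, at which 2 of the 4 values shown sit.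

The compounds shown leave open what a nitrile or a chlorine in place of the trifluoromethyl would give on either core. Going by these compounds, it also remains open how a carboxylic acid or an amine on that phenyl ring would read in this assay.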